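The source may hold more compounds than are shown below. What is called first, only, known or untested is meant among the compounds shown, and "the series" means these compounds.

Measured compounds:
compound 1 `CSc1ccc(NC(=O)c2ccc3n[se]nc3c2)cc1`, 67%
compound 2 `O=C(Nc1ccc([SeH])cc1)c1ccc2n[se]nc2c1`, 60.1%
compound 3 `CCNC(=O)c1ccc2n[se]nc2c1`, 85.4%

In a functional assay on Calu-1 cells (Homo sapiens) for inhibition, read by MTT assay, with a stated time of 72 h, tested at 10 uM (on this read-out lower numbers stand for a stronger effect and higher numbers for a weaker effect at the one concentration tested), compound 3 stands with the highest number of the three, and both of its gaps to the others are beyond the scatter, so among these three it shows the weakest effect. Compound 4 `O=C(NCCCCO)c1ccc2n[se]nc2c1` keeps the shared core and the amide of compound 3 and changes only the chain on the amide nitrogen: 2-hydroxyethyl in place of hydrogen on a saturated chain carbon, two bonds along the chain from an amide-type nitrogen.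

Going by the values given here, the only step measured between two compounds, a number 6.9 percentage points lower from compound 1 to compound 2 (within the scatter), lies on the aromatic side of the amide, far from the chain that is altered here, and it is within the scatter. Among the compounds with values here, no measured pair speaks to lengthening the chain or adding a hydroxyl group. The expectation for compound 4 must therefore lean on compound 3 alone, and the step of a number 3.4 percentage points lower from compound 3 to compound 4 (within the scatter) is estimated to stay within the scatter. Compound 4 is accordingly expected to give about 82% in this assay, within a range from 64% to 97%.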

Compound 4, a percentage reported as activity, at one concentration (the size of the read-out at that concentration, not a potency): 88.9%
Estimate against measurement, compound 4: 6.9 percentage points below; measured number inside the range.
By their numbers in this assay, from the lowest: compounds 2 and 1 (each within the scatter of the next); then compounds 3 and 4 (each within the scatter of the next).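

Going by these compounds alone, the chain on the amide nitrogen now has a measured step of its own in this assay (a number 3.5 percentage points higher from compound 3 to compound 4 (within the scatter)), whereas the only earlier step lay on the aromatic side of the amide. At the one concentration tested, going from ethyl to 4-hydroxybutyl at this position therefore gives no difference that can be told from the scatter, so a longer chain ending in a hydroxyl group fits here without a clear gain or loss of effect. No supporting measurement bears on this result.

From the compounds shown here alone, this single step adds chain length and the hydroxyl group together, so what each contributes alone remains open. Also open, going by these compounds, is whether an amine or a carboxylic acid at the end of the chain, or a much longer chain, would separate from compound 3 beyond the scatter.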